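Hydroxy in place of hydrogen: working notes on the series

The source may hold more compounds than are shown below. What is called first, only, known or untested is meant among the compounds shown, and "the series" means these compounds.

Measured in an ADME assay on HeLa cells (Homo sapiens) for cytotoxicity, read by resazurin assay, with a stated time of 65 h (on this read-out higher numbers stand for an effect only at larger amounts of compound and lower numbers for an effect already at smaller amounts), as follows
- compound 1 `CCCCc1cc(C(=O)OCC)c(NC(=O)c2ccc([N+](=O)[O-])o2)s1` gives > 20000 nM (a limit)
- compound 2 `CCCCOC(=O)c1cc(CC)sc1NC(=O)c1ccc([N+](=O)[O-])o1` gives > 20000 nM (a limit)
- compound 3 `CCNC(=O)c1cc(CC)sc1NC(=O)c1ccc([N+](=O)[O-])o1` gives > 20000 nM (a limit)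

Within the data shown here, compound 3 reads only as a limit, and the whole series so far rests on the limit of > 20000 nM in this assay, at which 3 of the 3 values shown sit, with no number to rank it by. Compound 4 `CCc1cc(C(=O)NCCO)c(NC(=O)c2ccc([N+](=O)[O-])o2)s1` differs from compound 3 by hydroxy in place of hydrogen on a saturated chain carbon, two bonds along the chain from an amide-type nitrogen and so turns ethylamino into (2-hydroxyethyl)amino. Among the measured compounds shown here, the only measured step that bears on this is a step that the two limits leave unreadable from compound 2 to compound 3 and it gives no size to carry over. No step beyond the scatter is therefore expected in this assay and another limit is the likeliest report. The expected step is a step that the limit leaves unreadable from compound 3 to compound 4 on this estimate. Compound 4 is estimated at 25000 nM with an expected range of 10000 nM to 50000 nM for its value.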

Compound 4, half-maximal effective concentration: > 20000 nM
Compound 4 gave a limit, no number; the forecaster's own chance of this, stated with the estimate: 85%; the middle value lies beyond the limit too.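

In this assay compound 4 gives > 20000 nM, a limit, and the steps to it from compound 2 and compound 3 cannot be read. The compounds shown leave open how they rank against one another, as all of them rest on one reading: the limit of > 20000 nM in this assay, at which 4 of the 4 values shown sit.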